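Methyl in place of tert-butyl on a weakly cytotoxic scaffold

A few compounds are considered here, and "the series" means these few. Any claim that something is new, unique, unknown or untested is made for them only; others in the source may bear on it.

Compound 1, `Cc1ccc(-c2nnc(SCCCN3CCN(c4cccc(Cl)c4)CC3)[nH]2)cc1`: 257000 nM in a functional assay on U-937 cells (Homo sapiens) for cytotoxicity, read by MTT assay, with a stated time of 24 h; on this read-out lower numbers stand for stronger inhibition and higher numbers for weaker inhibition
Compound 2, `CC(C)(C)c1ccc(-c2nn(CCCN3CCN(c4ccccc4)CC3)c(=S)[nH]2)cc1`: 88900 nM in this assay
Compound 3, `CC(C)(C)c1ccc(-c2nn(CCCN3CCN(c4cccc(Cl)c4)CC3)c(=S)[nH]2)cc1`: only a limit, > 300000 nM, in this assay

Compound 3 stands at the weak end of what has been measured. In this assay compound 3 gives no number at all, only the limit > 300000 nM. This is the point described by the limit of > 300000 nM in this assay, at which 1 of the 3 values shown sits. Among the measured compounds shown here, the single step that has been measured is an at least 3.3-fold higher number from compound 2 to compound 3 (0.52 log units; beyond the scatter). Compound 2 gives 88900 nM in this assay.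

Compound 4, `Cc1ccc(-c2nn(CCCN3CCN(c4cccc(Cl)c4)CC3)c(=S)[nH]2)cc1`, is compound 3 with a smaller group on the distant ring: methyl in place of tert-butyl on an aromatic carbon. For the measured compounds named here, no measured step touches this position, so the size of its effect cannot be read from the data. Going by the values given here, the one measured step concerns the chloro group and says nothing about tert-butyl against methyl. Compound 1 carries the same methyl group and the same chloro group as compound 4, though on a differently arranged core, and in this assay compound 1 gives 257000 nM, which is also weak.

Compound 4 is therefore expected to remain weak, with an estimate of 300000 nM and a likely span from 100000 nM to 900000 nM. The expected step of a number no higher from compound 3 to compound 4 (the limit leaves the size open) is none beyond the scatter, and a second limit is the likeliest outcome.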

Compound 4, half-maximal inhibitory concentration: > 300000 nM
Compound 4: a limit, no number (the forecaster's own chance of this, stated with the estimate: 55%); the middle value lies on the limit itself.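

Compound 3 and compound 4 each give only a limit, not a number, in this assay, so the step between them cannot be read, and the change from tert-butyl to methyl has no measurable size here: the limit of > 300000 nM in this assay, at which 2 of the 4 values shown sit.

The compounds shown leave open whether 4-(tert-butyl)phenyl and 4-methylphenyl differ at all in cytotoxicity on this shared core.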